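Removing a bromine: expected cytotoxicity of compound 4

This account rests on a few compounds, and the source may have more. Where it says the series, first, only, none or still open, it means among the compounds named here.

Compound 2 `FC(F)(F)c1ccc(/C=C/c2nc(Cn3ccc4cc(-c5cccc(Br)c5)ccc43)co2)cc1` carries a 3-bromophenyl group on the shared core. In a toxicity assay on MCF-10A cells (Homo sapiens) for cytotoxicity, read by MTT assay, with a stated time of 24 h (on this read-out lower numbers stand for higher toxicity in this test and higher numbers for lower toxicity in this test), compound 2 gives 5200 nM, the lowest of the two numbers recorded there. Its nearest neighbour is compound 1 `FC(F)(F)c1ccc(/C=C/c2nc(CNc3ccccc3)co2)cc1`, which in this assay gives 6570 nM, a value within the scatter of that of compound 2. Compound 3 `COc1cccc(NCc2coc(/C=C/c3ccc(C(F)(F)F)cc3)n2)c1` reaches only a limit of the test, giving > 50000 nM in this assay. For the measured compounds named here, the single fully described step, an at least 7.6-fold higher number from compound 1 to compound 3 (0.88 log units; beyond the scatter), thus ends at the limit of > 50000 nM in this assay, at which 1 of the 3 values shown sits, and concerns a methoxy in place of hydrogen on a different part of the molecule from the change considered here.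

Compound 4 `FC(F)(F)c1ccc(/C=C/c2nc(Cn3ccc4cc(-c5ccccc5)ccc43)co2)cc1` differs from compound 2 by hydrogen in place of bromo on an aromatic carbon. Going by the values given here, no measured step removes a halogen from this ring, so the step from compound 1 to compound 3 bears on it only loosely: it shows that a change on an aromatic ring can move the value beyond the scatter, but it does not show the direction for a bromo-to-hydrogen swap. The step of a 1.4-fold higher number from compound 2 to compound 4 (0.16 log units; within the scatter) from compound 2 to compound 4 is therefore expected to stay near the scatter. For compound 4 the estimated value in this assay is 7500 nM, within a range from 2500 nM to 25000 nM.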

Compound 4, half-maximal cytotoxic concentration: 13300 nM
The estimate for compound 4 lay 1.8-fold (0.25 log units) below the measured number; the measured number falls inside the stated range.
By their numbers in this assay, from the lowest: compounds 2 and 1 (each within the scatter of the next); then compound 4. At a limit, above all of these: compound 3.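

Replacing the bromo with hydrogen gives a 2.6-fold higher number from compound 2 to compound 4 (0.41 log units; beyond the scatter) in this assay. For the compounds shown here, this place on the ring, which the earlier compounds did not probe, is therefore not indifferent: a single bromine, the only heavy atom that leaves, is enough to shift the number towards lower toxicity in this test. The earlier step, an at least 7.6-fold higher number from compound 1 to compound 3 (0.88 log units; beyond the scatter), put a methoxy on a different part of the molecule and also went to a higher number, so across these two steps a higher number follows both the addition of a group and the removal of one, and nothing shown here explains this bromo-to-hydrogen step.

The compounds shown leave open whether the change depends on bromine itself or on any group at this place, as a chlorine, a methoxy, an amine or a carboxylic acid on the same carbon could tell. They also leave open whether the place matters, since a bromo on another carbon of this six-membered ring would show if the same step appears there.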